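The compounds below may be only part of what the source reports. "The series", "measured", "known", "first", "only" and "open" are said of these compounds alone.

Compound 3 `COc1ccc(/C=C\c2cc(OC)c(OC)c(OC)c2)cc1OCc1ccc(CN2CC[C@@H](C(=O)O)C2)cc1` carries a 3-carboxypyrrolidin-1-yl group on the shared core. In a functional assay on HepG2 cells (Homo sapiens) for antiproliferative activity, read by CCK-8 assay, with a stated time of 48 h (on this read-out lower numbers stand for stronger inhibition and higher numbers for weaker inhibition), compound 3 gives 2300 nM, the lowest of the two numbers shown. Its closest relative, compound 1 `COc1ccc(/C=C\c2cc(OC)c(OC)c(OC)c2)cc1OCc1ccc(CN2CC[C@H](C(=O)O)C2)cc1`, differs only in the configuration drawn at one ring carbon, and compound 1 gives 6400 nM; the step of a 2.8-fold lower number from compound 1 to compound 3 (0.44 log units; beyond the scatter) is modest but beyond the scatter. Compound 2 `COc1ccc(/C=C\c2cc(OC)c(OC)c(OC)c2)cc1OCc1ccc(CN2CCCC[C@H]2C(=O)O)cc1` bears a 2-carboxypiperidin-1-yl group instead. For compound 2 this assay reports only a limit, > 10000 nM. The step of an at least 4.3-fold lower number from compound 2 to compound 3 (0.63 log units; beyond the scatter) shows the pyrrolidine acid giving the lower number.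

Compound 4 `COc1ccc(/C=C\c2cc(OC)c(OC)c(OC)c2)cc1OCc1ccc(CN2CCCCC2C(=O)NCCN)cc1` is the next step from compound 3: 2-((2-aminoethyl)carbamoyl)piperidin-1-yl in place of 3-carboxypyrrolidin-1-yl on a saturated chain carbon bound to an aromatic carbon. The change brings in the six-membered piperidine ring seen in compound 2 and removes the free acid, replacing it with an amide carrying a basic amine. Because the piperidine partner compound 2 sits at the limit (the limit of > 10000 nM in this assay, at which 1 of the 3 values shown sits), a higher number than compound 3 is expected, with compound 4 estimated near 8000 nM (range 2500 nM to 25000 nM), a step of a 3.5-fold higher number from compound 3 to compound 4 (0.54 log units; beyond the scatter).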

Compound 4, half-maximal inhibitory concentration: 4800 nM
Compound 4: middle estimate off by 1.7-fold (0.22 log units), on the high side; low and high end bracket the measured number.
By their numbers in this assay, from the lowest: compound 3; then compounds 4 and 1 (each within the scatter of the next). At a limit, above all of these: compound 2.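

In this assay, replacing the free acid on the piperidine ring with a 2-aminoethyl amide gives an at least 2.0-fold lower number from compound 2 to compound 4 (0.31 log units; beyond the scatter), so a piperidine on this saturated chain carbon can give a measured number and not only a limit. That step starts from a limit held by compound 2, not from a true number: the limit of > 10000 nM in this assay, at which 1 of the 4 values shown sits. The same change still gives a 2.1-fold higher number from compound 3 to compound 4 (0.32 log units; beyond the scatter), which leaves the pyrrolidine acid of compound 3 with the lowest number shown, while a 1.3-fold lower number from compound 1 to compound 4 (0.12 log units; within the scatter) separates the new amide from the other pyrrolidine acid by no more than the scatter.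

From the compounds shown here alone, it remains open how the 2-aminoethyl amide would read on the pyrrolidine ring, or how a longer 3-aminopropyl chain would read on the piperidine amide. The entering group also has no defined stereocentre, so the effect of a single configuration in compound 4 is unknown, a question that arises from the earlier pair: the fact that compounds 1 and 3 differ only in the configuration as drawn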